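This account rests on a few compounds, and the source may have more. Where it says the series, first, only, none or still open, it means among the compounds named here.

Three compounds share one core and differ only in the aryl group carried by the amide nitrogen. Compound 1 `CCCCCN1C(=O)C/C(=C\c2cccc(C(=O)Nc3cccc(F)c3)c2)C1=O` was tested in an ADME assay on SW480 cells (Homo sapiens) for cytotoxicity, read by MTT assay, with a stated time of 72 h; a higher number here means a weaker inhibitor, a lower number a stronger inhibitor. In this assay compound 1 reaches only a limit of the assay, > 100000 nM. Compound 2 `Cc1ccc(NC(=O)c2cccc(/C=C3\CC(=O)N(c4ccccc4)C3=O)c2)cc1C` likewise gives only a limit in this assay, > 100000 nM. Compound 3 `COc1cc(NC(=O)c2cccc(/C=C3\CC(=O)N(c4ccccc4)C3=O)c2)cc(OC)c1OC` also gives only a limit in this assay, > 100000 nM. Among the measured compounds shown here, compound 2 therefore stands where every measured compound stands, and no measured compound is set apart from the others, so no step between measured compounds can be counted.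

Compound 4 `CCc1ccc(NC(=O)c2cccc(/C=C3\CC(=O)N(c4ccccc4)C3=O)c2)cc1` differs from compound 2 in one place: 4-ethylphenyl in place of 3,4-dimethylphenyl on an amide-type nitrogen. The 3,4-dimethylphenyl leaves and a 4-ethylphenyl enters on an amide-type nitrogen whose other neighbour is a carbonyl carbon; the two compounds have the same atoms, joined differently.

Because all three measured values sit at the limit of > 100000 nM in this assay, at which 3 of the 3 values shown sit, no step beyond the usual scatter is expected from compound 2 to compound 4 in this assay, and the expected step that the limit leaves unreadable from compound 2 to compound 4 is taken as none. Compound 4 is estimated at 150000 nM, within 50000 nM to 500000 nM, most likely again reported only as a limit.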

Compound 4, half-maximal inhibitory concentration: > 100000 nM
Compound 4: a limit, no number; the forecaster's own chance of this, stated with the estimate: 85%; the middle value is on the limit's open side.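

In this assay compound 4 gives > 100000 nM, a limit of the assay and not a number. Among the compounds shown here, compound 2 is likewise only a limit, so no step from compound 2 to compound 4 can be read. The compounds shown leave open how they rank against one another and which structural change would give a readable value in this assay.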